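Amide chain branching from compound 2 to compound 4

The source may report more compounds than this note shows. Statements on the series, on what has been measured and on what is new or still open speak of the compounds shown alone.

Measured so far:
compound 1 `O=C(NC[C@@H]1C[C@H]1c1cccc2c1C[C@@H](CCCCc1ccccc1)O2)C1CC1`: 5 nM
compound 2 `CCC(=O)NC[C@@H]1C[C@H]1c1cccc2c1C[C@@H](CCCCc1ccccc1)O2`: 2 nM
compound 3 `CCCC(=O)NCCCc1cccc2c1C[C@@H](CCCCc1ccccc1)O2`: 30 nM

In an assay on NIH3T3 cells for binding affinity to melatonin receptor type 1B (Homo sapiens) (a lower number here means a stronger inhibitor, a higher number a weaker inhibitor), compound 2 gives the lowest number of the three, beyond the scatter from both compound 1 and compound 3. Compound 4 `CC(C)C(=O)NC[C@@H]1C[C@H]1c1cccc2c1C[C@@H](CCCCc1ccccc1)O2` differs from compound 2 by methyl in place of hydrogen on a saturated chain carbon bound to a carbonyl carbon and a saturated chain carbon, or ethyl to isopropyl on the carbonyl. The step that bears on it is a 2.5-fold lower number from compound 1 to compound 2 (0.40 log units; beyond the scatter), a modest change on the same carbonyl. The step of a 15-fold higher number from compound 2 to compound 3 (1.18 log units; beyond the scatter) sits elsewhere and does not bear on it. A small step is expected in this assay, in either direction or none beyond the scatter. Compound 4 is therefore expected at 3 nM (range 1.2 nM to 8 nM), meaning an estimated step of a 1.5-fold higher number from compound 2 to compound 4 (0.18 log units; within the scatter).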

Compound 4, inhibition constant: 90 nM
For compound 4 the middle estimate is 30-fold (1.48 log units) below the measured one, outside the stated range (above it).
By their numbers in this assay, from the lowest: compound 2; then compound 1; then compound 3; then compound 4.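

In this assay, one added methyl on the saturated chain carbon bound to the carbonyl carbon matters far more than the earlier carbonyl change indicated: a 45-fold higher number from compound 2 to compound 4 (1.65 log units; beyond the scatter). Cyclopropyl and isopropyl on the carbonyl carbon are also far apart, with an 18-fold higher number from compound 1 to compound 4 (1.26 log units; beyond the scatter), so substitution at this carbon does not by itself set the number. Nothing available accounts for this gap. Still open, from the compounds shown here alone, is whether a tert-butyl or a longer chain on the carbonyl carbon would fall nearer compound 2 or compound 4.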